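This account rests on a few compounds, and the source may have more. Where it says the series, first, only, none or still open, it means among the compounds named here.

In a functional assay on ileum (Cavia porcellus) for antagonist activity (a higher number here means a weaker inhibitor, a lower number a stronger inhibitor), compound 1 `CCCc1c(OCC(O)COc2ccc3c(O)c([N+](=O)[O-])c(=O)oc3c2)ccc(C(C)=O)c1O` gives 80 nM. Compound 2 `CCCc1c(OCC(O)COc2ccc3c(O)c([N+](=O)[O-])c(=O)oc3c2C)ccc(C(C)=O)c1O`, with a methyl in place of a hydrogen on an aromatic carbon, gives 25 nM, a modest change seen as a 3.2-fold lower number from compound 1 to compound 2 (0.51 log units; beyond the scatter). Compound 3 `CCCc1c(OCC(O)COc2ccc3c(O)c([N+](=O)[O-])c(=O)oc3c2CC)ccc(C(C)=O)c1O`, with ethyl in place of that hydrogen, gives 50 nM. This value lies within the scatter of both other compounds, as shown by a 1.6-fold lower number from compound 1 to compound 3 (0.20 log units; within the scatter) and by a 2.0-fold higher number from compound 2 to compound 3 (0.30 log units; within the scatter).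

Compound 4 `CCCc1c(OCC(O)COc2ccc3c(O)c([N+](=O)[O-])c(=O)oc3c2CCC)ccc(C(C)=O)c1O` lengthens the chain again: methyl in place of hydrogen on a saturated chain carbon, two bonds along the chain from an aromatic carbon. This puts a methyl in place of hydrogen on a saturated chain carbon, two bonds along the chain from an aromatic carbon, so ethyl becomes propyl. The closest measured parallel is the lengthening of methyl to ethyl, a 2.0-fold higher number from compound 2 to compound 3 (0.30 log units; within the scatter), which stayed within the scatter. On that single precedent, no step beyond the scatter is expected in this assay, and no firm direction can be assigned. The estimated step is a 1.2-fold higher number from compound 3 to compound 4 (0.08 log units; within the scatter). Compound 4 is expected at about 60 nM, within an estimated range of 25 nM to 150 nM.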

Compound 4, half-maximal inhibitory concentration: 200 nM
For compound 4 the middle estimate is 3.3-fold (0.52 log units) below the measured one; the measured number lies above the stated range.
By their numbers in this assay, from the lowest: compounds 2, 3 and 1 (each within the scatter of the next, the first and the last beyond it); then compound 4.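

Lengthening ethyl to propyl shows that this position does not accept every added carbon equally: the result is a 4.0-fold higher number from compound 3 to compound 4 (0.60 log units; beyond the scatter) in this assay while the earlier lengthening of methyl to ethyl stayed within the scatter. Propyl is the only group here that gives a weaker inhibitor than hydrogen, with a 2.5-fold higher number from compound 1 to compound 4 (0.40 log units; beyond the scatter) and the gain seen with methyl is lost entirely, with an 8.0-fold higher number from compound 2 to compound 4 (0.90 log units; beyond the scatter) leaving compound 4 as the weakest inhibitor of the four. No measurement at hand explains why this one added carbon matters so much.

On these data alone, whether a longer chain such as butyl raises the number further remains open. So does whether a branched isopropyl, or a propyl chain ending in an amine or a hydroxyl, would behave as propyl does.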